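The source may report more compounds than this note shows. Statements on the series, on what has been measured and on what is new or still open speak of the compounds shown alone.

Compound 1 `COc1ccc(Nc2nc(NCCCO)c3ccccc3n2)cc1`: 95.6 ug/mL
Compound 2 `CCCNc1nc(Nc2ccc(OC)cc2)nc2ccccc12`: 4.36 ug/mL

Both values come from a physicochemical assay for solubility, read by HPLC, in phosphate buffer, at pH 7.4; on this read-out higher numbers stand for higher solubility and lower numbers for lower solubility. Compound 2 holds the lower of the two numbers, and compound 1 stands above it by a margin beyond the scatter. Compound 3 `CNc1nc(Nc2ccc(OC)cc2)nc2ccccc12` departs from compound 2 in one place, (hydrogen in place of ethyl on a saturated chain carbon bound to a nitrogen on an aromatic ring). This is hydrogen in place of ethyl on a saturated chain carbon bound to a nitrogen on an aromatic ring, or propylamino to methylamino.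

Going by the values given here, only one measured step bears on this change: a 22-fold lower number from compound 1 to compound 2 (1.34 log units; beyond the scatter). There, hydrogen takes the place of hydroxy on the chain, so that large step involves a different group and is only a loose guide. Among the compounds with values here, no measured pair shows the shortening of the chain alone. A small rise in this assay is therefore expected, far smaller than that step and possibly not beyond the scatter. The expected change is a 1.6-fold higher number from compound 2 to compound 3 (0.21 log units; within the scatter). Compound 3 is estimated at 7 ug/mL, with an expected range from 2.5 ug/mL to 20 ug/mL.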

Compound 3, solubility: 6.61 ug/mL
Beside the measured number, compound 3's estimate is 1.1-fold (0.02 log units) above it; measured number inside the range.
By their numbers in this assay, from the lowest: compounds 2 and 3 (each within the scatter of the next); then compound 1.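

In this assay, going by these compounds alone, the step of a 1.5-fold higher number from compound 2 to compound 3 (0.18 log units; within the scatter) gives the first reading of a change in chain length alone at this position, propylamino to methylamino with no hydroxy group involved, and that step stays within the scatter. Within the data shown here, the step of a 14-fold lower number from compound 1 to compound 3 (1.16 log units; beyond the scatter), in which hydrogen takes the place of 2-hydroxyethyl, is large and beyond the scatter, so of these three compounds only compound 1, the one carrying the hydroxy group, stands apart from the others, while compound 2 and compound 3 cannot be told apart by their numbers. No evidence is available that would account for these numbers.

The compounds shown leave open whether a hydroxy group on a shorter or a longer chain at this position would stand level with compound 1 in this assay or nearer to compound 2 and compound 3. They also leave open how an amine or a carboxylic acid at the end of the chain would read, and whether a longer chain without any such group would stay as close to compound 2 as the methylamino compound does.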